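A few compounds are considered here, and "the series" means these few. Any claim that something is new, unique, unknown or untested is made for them only; others in the source may bear on it.

In a functional assay on PC-3 cells (Homo sapiens) for cytotoxicity, read by MTT assay, with a stated time of 72 h (on this read-out higher numbers stand for weaker inhibition of growth and lower numbers for stronger inhibition of growth), three compounds have readings. Compound 1 `CC(C)COC(=O)Nc1ccc([Se][Se]c2ccc(NC(=O)OCC(C)C)cc2)cc1` gives 48900 nM. Compound 2 `N#C[Se]c1ccc(NC(=O)Oc2ccc(F)cc2)cc1` gives 40400 nM. Compound 3 `O=C(Nc1ccc([Se][Se]c2ccc(NC(=O)Oc3ccccc3)cc2)cc1)Oc1ccccc1` gives 27200 nM. On these numbers compound 2 sits between compound 1 and compound 3, and its gaps to both lie within the usual scatter, so the three cannot be told apart on this read-out. Compound 4 `COc1ccc(OC(=O)Nc2ccc([Se]C#N)cc2)cc1` is the next to be measured in this assay. It differs from compound 2 by methoxy in place of fluoro on an aromatic carbon. Within the data shown here, no comparable step has been measured, so nothing in the data points toward either direction. The expected step, a 1.0-fold lower number from compound 2 to compound 4 (0.00 log units; within the scatter), is taken as none beyond the scatter. Compound 4 is accordingly estimated at 40000 nM, within a range from 18000 nM to 90000 nM.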

Compound 4, concentration for total growth inhibition: 44600 nM
Compound 4: the middle estimate sits 1.1-fold (0.05 log units) below what was measured, within the range that was stated.
By their numbers in this assay, from the lowest: compounds 3, 2, 4 and 1 (each within the scatter of the next).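

In this assay the first step read at this position, methoxy in place of fluoro on an aromatic carbon para to a large group, stays inside the scatter (a 1.1-fold higher number from compound 2 to compound 4 (0.04 log units; within the scatter)). At this position, then, the two groups cannot be told apart on this read-out, even with the added hydrogen-bond acceptor and the extra heavy atom of methoxy. Nothing available on these compounds speaks to why the reading holds.

Open, from the compounds shown here alone, is whether an amine or a carboxylic acid at this position would give a step beyond the scatter. A longer chain such as butoxy leaves the same question open.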